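The source may hold more compounds than are shown below. What is called first, only, known or untested is meant among the compounds shown, and "the series" means these compounds.

Measured so far:
Compound 1 `COc1ccc(/C=C/S(=O)(=O)Cc2ccc(OC)c(N)c2)c(OC)c1` gives 500 nM in a functional assay on DU-145 cells (Homo sapiens) for cytotoxicity, read by trypan blue exclusion, with a stated time of 96 h; a higher number here means a weaker inhibitor, a lower number a stronger inhibitor.
Compound 2 `COc1cc(OC)c(/C=C/S(=O)(=O)Cc2ccc(OC)c(N)c2)c(OC)c1` gives 4 nM in this assay.
Compound 3 `COc1ccc(CS(=O)(=O)/C=C/c2c(OC)cc(OCCCC(=O)O)cc2OC)cc1N` gives 25000 nM in this assay.

Compound 2 has the lowest number of the three in this assay; both the step of a 130-fold lower number from compound 1 to compound 2 (2.10 log units; beyond the scatter) and the step of a 6300-fold higher number from compound 2 to compound 3 (3.80 log units; beyond the scatter) lie beyond the scatter. Compound 4 `COc1ccc(C(Nc2cc(CS(=O)(=O)/C=C/c3c(OC)cc(OC)cc3OC)ccc2OC)C(=O)O)cc1` differs from compound 2 by carboxy(4-methoxyphenyl)methyl in place of hydrogen on a nitrogen on an aromatic ring. Within the data shown here, no measured step touches the nitrogen on the aromatic ring. Among the measured compounds shown here, the one step that brings in a carboxy group, a 6300-fold higher number from compound 2 to compound 3 (3.80 log units; beyond the scatter), does so on a saturated chain carbon bound to an oxygen on an aromatic ring, and it bears only loosely here. A sizeable move toward a higher number is nonetheless expected for compound 4, a 50-fold higher number from compound 2 to compound 4 (1.70 log units; beyond the scatter), smaller than that seen for compound 3. Compound 4 is estimated at 200 nM, within a range of 20 nM to 5000 nM.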

Compound 4, half-maximal inhibitory concentration: 100 nM
Compound 4: the middle estimate sits 2.0-fold (0.30 log units) above what was measured, within the range that was stated.
By their numbers in this assay, from the lowest: compound 2; then compound 4; then compound 1; then compound 3.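

In this assay, the nitrogen on the aromatic ring is now probed directly: a 25-fold higher number from compound 2 to compound 4 (1.40 log units; beyond the scatter) is a large step, beyond the scatter, for carboxy(4-methoxyphenyl)methyl in place of hydrogen. That single change brings in both a carboxy group and a six-membered aromatic ring, so the step cannot be divided between them. Nothing available bears on the cause of this step.

Still open, going by these compounds, is how the number would move with a simple methyl group on this nitrogen, or with a 4-methoxybenzyl group lacking the carboxylic acid. On these data alone, the methyl ester of compound 4 is equally open.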